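Swapping an Ethoxy for a Trifluoromethyl on the Core

The compounds below may be only part of what the source reports. "The series", "measured", "known", "first", "only" and "open" are said of these compounds alone.

Compound 1 `Cc1c(C(=O)Nc2c(F)cc(-c3cccc(F)c3)cc2F)nc2ccc(C(F)(F)F)cc2c1O` gives 68.4% in a functional assay on Hep 3B2 cells (Homo sapiens) for antiproliferative activity, read by MTT assay, with a stated time of 24 h, tested at 100 ug/mL; on this read-out lower numbers stand for a weaker effect and higher numbers for a stronger effect at the one concentration tested. Among the compounds with values here, compound 2 `CCOc1ccc2nc(C(=O)Nc3c(F)cc(-c4cccc(F)c4)cc3F)c(C)c(C(=O)O)c2c1` gives 65.3% in the same measurement, so the two numbers lie within the usual scatter of each other, and no step between them can be read. Compound 3 `Cc1c(C(=O)Nc2c(F)cc(-c3cccc(F)c3)cc2F)nc2ccc(C(F)(F)F)cc2c1C(=O)O` differs from compound 2 in one place: trifluoromethyl in place of ethoxy on an aromatic carbon. Nothing measured here shows what this change does on its own, so the step from compound 2 to compound 3 is expected to be none beyond the scatter, that is a number 1.7 percentage points higher from compound 2 to compound 3 (within the scatter). Compound 3 is therefore estimated at 67%, between 50% and 82%.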

Compound 3, a percentage reported as inhibition, at one concentration (the size of the read-out at that concentration, not a potency): 72.3%
Estimate against measurement, compound 3: 5.3 percentage points below; measured number inside the range.
By their numbers in this assay, from the lowest: compounds 2, 1 and 3 (each within the scatter of the next).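

In this assay, trifluoromethyl in place of ethoxy on an aromatic carbon gives a number 7 percentage points higher from compound 2 to compound 3 (within the scatter) and so does not separate these two groups at this position. Carboxy in place of hydroxy on an aromatic carbon, a single change elsewhere on the shared core, gives a number 3.9 percentage points higher from compound 1 to compound 3 (within the scatter) and does not separate those two groups either. Nothing measured here explains either result. As far as these compounds go, whether an amine or a longer chain such as propoxy in place of trifluoromethyl would give a step beyond the scatter stays open. So does how these compounds compare at other concentrations.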